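A few compounds are considered here, and "the series" means these few. Any claim that something is new, unique, unknown or untested is made for them only; others in the source may bear on it.

Among the measured compounds shown here, compound 1 `CN1CCN(c2nc(-c3cc(Cl)ccc3Cl)nc3[nH]cnc23)CC1` and compound 2 `Oc1ccc(-c2nc(N3CCCCC3)c3nc[nH]c3n2)cc1` are the two measured members. In an assay on cells for displacement of a labelled ligand from adenosine receptor A3 (Homo sapiens), read by scintillation counting and radioligand binding, with a stated time of 180 min, tested at 10 uM (a higher number here means more inhibition at the concentration tested (going by the name of the read-out), a lower number less inhibition), compound 1 reports only a limit, > 80%. In this assay compound 2 likewise sits at a limit, > 80%. Both share (the limit of > 80% in this assay, at which 2 of the 2 values shown sit), so compound 2 stands at the top of what is shown, with no numbered value to rank it. Compound 3 `CN1CCN(c2nc(-c3ccc(O)cc3)nc3[nH]cnc23)CC1` differs from compound 2 by 4-methylpiperazin-1-yl in place of piperidin-1-yl on an aromatic carbon. Compound 1 carries the same 4-methylpiperazin-1-yl group and also reaches the limit > 80%. For the measured compounds named here, no measured step covers this change; the expected step that the limit leaves unreadable from compound 2 to compound 3 is none beyond the scatter. Compound 3 is estimated at 85%, within 70% to 95%, and is expected to be reported again as a limit.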

Compound 3, a percentage reported as inhibition, at one concentration (the size of the read-out at that concentration, not a potency): 48%
Estimate against measurement, compound 3: 37 percentage points above; measured number outside the range, below it.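

In this assay the 4-methylpiperazin-1-yl group does not stand in for piperidin-1-yl when 4-hydroxyphenyl is present, giving a number at least 32 percentage points lower from compound 2 to compound 3 (beyond the scatter) on this one change. The number is higher with the same 4-methylpiperazin-1-yl group and 2,5-dichlorophenyl, and the aryl change alone gives a number at least 32 percentage points lower from compound 1 to compound 3 (beyond the scatter) in the same assay, so the effect of the amine ring depends on the aryl group. Both steps are bounds and not exact sizes, because each starts from a compound at a limit: the limit of > 80% in this assay, at which 2 of the 3 values shown sit.

Still open, as far as these compounds go, is how an unsubstituted piperazin-1-yl or a morpholin-4-yl group would read at this position, which would separate the ring nitrogen from its methyl. Also open, from the compounds shown here alone, is how a 4-chlorophenyl group would read in place of 4-hydroxyphenyl.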